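Branched chain carbamates in an intestinal cholesterol acyltransferase assay

The compounds below may be only part of what the source reports. "The series", "measured", "known", "first", "only" and "open" are said of these compounds alone.

Measured compounds:
compound 1, `CCCCCCCCCCCOC(=O)NC(=O)Oc1c(C(C)C)cccc1C(C)C`, 140 nM
compound 2, `CCCCCCCCCCCCOC(=O)NC(=O)Oc1c(C(C)C)cccc1C(C)C`, 21 nM
compound 3, `CCCCCCCCCCCCC(C)OC(=O)NC(=O)Oc1c(C(C)C)cccc1C(C)C`, 17 nM

All three share one core and differ only in the alkyl chain on the carbamate. In an assay on microsomes from intestine for inhibition of acyl-CoA:cholesterol acyltransferase (Oryctolagus cuniculus) (a higher number here means a weaker inhibitor, a lower number a stronger inhibitor), compound 1 gives 140 nM. The change methyl in place of hydrogen on a saturated chain carbon, ten or more bonds along the chain from an oxygen next to a carbonyl group brings a 6.7-fold lower number from compound 1 to compound 2 (0.82 log units; beyond the scatter). Compound 3 gives 17 nM; the difference between the chains of compound 1 and compound 3 is not broken down here, and the values of compound 2 and compound 3 lie within the scatter of each other.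

Compound 4, `CCCCCCCCCCCCC(C)(C)OC(=O)NC(=O)Oc1c(C(C)C)cccc1C(C)C`, is not yet measured. It carries the same kind of change as the step from compound 1 to compound 2, namely (methyl in place of hydrogen on a saturated chain carbon bound to an oxygen next to a carbonyl group and two saturated chain carbons), but the place differs: here the methyl enters on a carbon bound to an oxygen next to a carbonyl group and two saturated chain carbons, whereas in compound 2 it entered at a remote place along the chain from that oxygen. Because a 6.7-fold lower number from compound 1 to compound 2 (0.82 log units; beyond the scatter) came from a remote position, it gives little guidance for a methyl entering at the carbon bound to the oxygen. Compound 4 is therefore expected to give a step of a 1.5-fold higher number from compound 3 to compound 4 (0.17 log units; within the scatter), mostly within the scatter. The estimate for compound 4 is 25 nM, between 8 nM and 80 nM.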

Compound 4, half-maximal inhibitory concentration: 21 nM
The estimate for compound 4 lay 1.2-fold (0.08 log units) above the measured number; low and high end bracket the measured number.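

In this assay, methyl in place of hydrogen on a saturated chain carbon bound to an oxygen next to a carbonyl group and two saturated chain carbons gives a 1.2-fold higher number from compound 3 to compound 4 (0.09 log units; within the scatter), so this step shows no measurable effect of the added methyl. Set beside the earlier step, the change does not carry over in size from one core to another in this series: the same change on two cores in this assay, a 6.7-fold lower number (0.82 log units; beyond the scatter) from compound 1 to compound 2 and a 1.2-fold higher number (0.09 log units; within the scatter) from compound 3 to compound 4, 8.2-fold (0.92 log units) apart, beyond the scatter of two such steps. The two steps differ both in the place where the methyl enters and in the chain that receives it, and they do not tell which of these accounts for the gap, nor how the change would behave on any other chain.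

The compounds shown leave open how a longer chain, or a chain ending in a carboxylic acid or an amine, would read in this assay. They also leave open whether an ethyl group on the same carbon would behave as the methyl does, and what an amide or a urea would give in place of the carbamate.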